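Replacing the 4-(trifluoromethoxy)phenyl group of compound 3

The source may hold more compounds than are shown below. What is called first, only, known or untested is meant among the compounds shown, and "the series" means these compounds.

Measured in an ADME assay on L02 cells (Homo sapiens) for antiproliferative activity, read by MTT assay, with a stated time of 48 h; a lower number here means a stronger inhibitor, a higher number a weaker inhibitor:
- Compound 1 `CCn1c(C(=O)NCCCN(C)C)ccc1C(CC)(CC)c1ccc(OCCC(O)(CC)CC)c(C)c1`: 2420 nM
- Compound 2 `CCn1c(C(=O)NCCN(C)C)ccc1C(CC)(CC)c1ccc(OCCC(O)(CC)CC)c(C)c1`: 990 nM
- Compound 3 `CCn1c(C(=O)Nc2ccc(OC(F)(F)F)cc2)ccc1C(CC)(CC)c1ccc(OCCC(O)(CC)CC)c(C)c1`: > 50000 nM (a limit, not a number)

Compound 3 has no number of its own, as its result sits at the limit of > 50000 nM in this assay, at which 1 of the 3 values shown sits. Compound 4 `CCn1c(C(=O)NC(CC(=O)O)C(=O)OC)ccc1C(CC)(CC)c1ccc(OCCC(O)(CC)CC)c(C)c1` keeps the shared core and differs from compound 3 by one change: a group of 9 heavy atoms (5 carbon, 4 oxygen; no ring) in place of a group of 11 heavy atoms (7 carbon, 1 oxygen, 3 fluorine; one six-membered aromatic ring of carbon only), on an amide-type nitrogen. The new group has no ring and, like the group it replaces, carries no net charge.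

For the measured compounds named here, two measured steps bear on this position. They are an at least 20-fold higher number from compound 1 to compound 3 (1.31 log units; beyond the scatter) and an at least 50-fold higher number from compound 2 to compound 3 (1.70 log units; beyond the scatter), both large, and each removes a dimethylamino chain. The third, a 2.4-fold lower number from compound 1 to compound 2 (0.39 log units; beyond the scatter), is modest and only alters that chain. Compound 4 has no such chain, so it is not expected to regain the values of compound 1 or compound 2. At most a small move toward a lower number is expected, and the result may again be a limit.

The expected change is an at least 2.0-fold lower number from compound 3 to compound 4 (0.30 log units; that floor lies within the scatter). In this assay the estimate for compound 4 is 25000 nM, expected to lie between 8000 nM and 50000 nM.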

Compound 4, half-maximal inhibitory concentration: 7590 nM
For compound 4 the middle estimate is 3.3-fold (0.52 log units) above the measured one, and the stated range ends above it.
By their numbers in this assay, from the lowest: compound 2; then compound 1; then compound 4. At a limit, above all of these: compound 3.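

In this assay, for the compounds shown here, the change on the amide-type nitrogen gives an at least 6.5-fold lower number from compound 3 to compound 4 (0.81 log units; beyond the scatter), so a dimethylamino chain is not the only kind of group here that yields a measured number. Compound 3 still gives only a limit, not a number: the limit of > 50000 nM in this assay, at which 1 of the 4 values shown sits. The chains carrying a dimethylamino group still give the lower numbers, with a 7.7-fold higher number from compound 2 to compound 4 (0.88 log units; beyond the scatter) and a 3.1-fold higher number from compound 1 to compound 4 (0.50 log units; beyond the scatter).

The new group brings in more than one feature at once, so these compounds cannot show whether its free acid, its methyl ester or simply the loss of the 4-(trifluoromethoxy)phenyl ring accounts for the step. Also open, going by these compounds, is how a diethylamino chain, or a simple chain ending in a hydroxyl group, would read in this assay on this same nitrogen.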